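Replacing 1H-pyrazol-4-yl with phenyl in compound 3

The compounds below may be only part of what the source reports. "The series", "measured", "known", "first", "only" and "open" are said of these compounds alone.

compound 1 `CCC(c1cc2cccnc2cc1F)n1cnc2ncc(-c3cn[nH]c3)nc21` - "not determined" (no result reported)
compound 2 `CCC(c1ccc2ncccc2c1F)n1cnc2ncc(-c3ccc(C(=O)OC)c(F)c3)nc21` - "not determined" (no result reported)
compound 3 `c1cnc2ccc(Cn3cnc4ncc(-c5cn[nH]c5)nc43)cc2c1` - 2890 nM

In a functional assay on NCI-H1993 cells (Homo sapiens) for inhibition, read by CCK-8 assay, with a stated time of 72 h (a lower number here means a stronger inhibitor, a higher number a weaker inhibitor), compound 3 is the only one of the series with a number, at 2890 nM. Compounds 1 and 2 have no reported result, so compound 3 cannot be ranked against anything yet, and it serves as the sole reference point.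

The next compound to be tested is compound 4 `c1ccc(-c2cnc3ncn(Cc4ccc5ncccc5c4)c3n2)cc1`, which has phenyl in place of 1H-pyrazol-4-yl on an aromatic carbon. The rest of its structure matches compound 3. Within the data shown here, no pair of measured compounds shows what this exchange does, so any forecast carries wide uncertainty.

A modest loss of inhibition in this assay is expected, close to the edge of the usual scatter, and the expected change is a 2.1-fold higher number from compound 3 to compound 4 (0.32 log units; beyond the scatter). For compound 4 the estimated value is 6000 nM, with an expected range from 1800 nM to 20000 nM.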

Compound 4, half-maximal inhibitory concentration: 7490 nM
For compound 4 the middle estimate is 1.2-fold (0.10 log units) below the measured one, within the range that was stated.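

In this assay, among these compounds, phenyl in place of 1H-pyrazol-4-yl on this aromatic carbon gives a 2.6-fold higher number from compound 3 to compound 4 (0.41 log units; beyond the scatter), the first measured step, which shows that inhibition responds to the group at this position. The change is modest: with a six-membered aromatic ring of carbon only at this position, compound 4 still gives a measurable value, so the hydrogen-bond donor and acceptor of 1H-pyrazol-4-yl are not required for activity in these cells. No measured data on the compounds bear on why the number rises.

This single step cannot separate the effect of removing the ring nitrogens from that of changing the ring size. It also leaves open how pyridin-4-yl at this position, or a carboxylic acid or an amine on the phenyl ring, would compare with compound 3.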